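Isopropyl in place of 2,3-dimethylphenyl

A few compounds are considered here, and "the series" means these few. Any claim that something is new, unique, unknown or untested is made for them only; others in the source may bear on it.

Results so far in a toxicity assay on NIH3T3 cells (Mus musculus) for cytotoxicity, read by resazurin assay (a lower number here means that less compound is needed, a higher number that more compound is needed for the effect), with the read-out as half-maximal effective concentration
- Compound 1 `Clc1ccc(NCc2cncn2Cc2ccc(-c3ccccc3)cc2)cc1-c1ccccc1` gives > 1000 nM as a limit
- Compound 2 `Cc1cccc(-c2cccc(NCc3cncn3Cc3ccccc3)c2)c1C` gives > 1000 nM as a limit
- Compound 3 `COC(=O)c1ccc(NCc2cncn2Cc2ccccc2C(C)(C)C)cc1-c1ccccc1` gives "not determined" (no result reported) as its entry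

Compound 2 stands at > 1000 nM which is a limit and not a number. It shares this position with compound 1, as the summary the limit of > 1000 nM in this assay, at which 2 of the 3 values shown sit, records, while compound 3 has no result. For the measured compounds named here, no step between two measured compounds can be read from these entries.

The account now moves to compound 4 `CC(C)c1cccc(NCc2cncn2Cc2ccccc2)c1` which carries isopropyl in place of 2,3-dimethylphenyl on an aromatic carbon, meta to a large group isopropyl in place of 2,3-dimethylphenyl on an aromatic carbon and is still to be measured. The expectation rests on compound 2 at > 1000 nM as a limit, so it is a loose one. In this assay the number is expected to stay high or to move higher, and the assay may again report only a limit. The expected size of the change is a step that the limit leaves unreadable from compound 2 to compound 4 in the direction of more compound being needed. For compound 4 the estimate is 3000 nM with an expected range from 1000 nM to 20000 nM in this reading.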

Compound 4, half-maximal effective concentration: > 1000 nM
Compound 4 was reported as a limit; the forecaster's own chance of this, stated with the estimate: 70%; the middle value lies beyond the limit too.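

In this assay compound 4 gives > 1000 nM, which is a limit and not a number. Compound 2 also stands at a limit, so no step between compound 2 and compound 4 can be read: the limit of > 1000 nM in this assay, at which 3 of the 4 values shown sit.

The compounds shown leave open how much of either compound is needed for the effect, and whether isopropyl in place of 2,3-dimethylphenyl shifts that amount at all.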